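The compounds below may be only part of what the source reports. "The series", "measured", "known", "first", "only" and "open" are said of these compounds alone.

Measured compounds in a functional assay on NCI-H460 cells (Homo sapiens) for inhibition; a higher number here means a weaker inhibitor of growth, a lower number a stronger inhibitor of growth:
- compound 1 `Nc1ccc(-c2nc3ccc(F)cc3s2)cc1I`: > 100000 nM (a limit of the assay)
- compound 2 `Cc1cc(-c2nc3c(F)cccc3s2)ccc1N`: 1000 nM

Compound 1 has no number in this assay, only a limit: the limit of > 100000 nM in this assay, at which 1 of the 2 values shown sits. Compound 2 gives a real reading of 1000 nM. Among the measured compounds shown here, the two measured compounds differ in more than one place, so the series offers no measured single-change step to use as a guide.

The next case is compound 3 `Nc1ccc(-c2nc3ccc(F)cc3s2)cc1Cl`, not yet measured. Its difference from compound 1 is chloro in place of iodo on an aromatic carbon. In short, this is chloro in place of iodo on an aromatic carbon, ortho to an amino group and meta to a large group.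

For the measured compounds named here, the only number in hand is that of compound 2 at 1000 nM, and it pulls the expectation toward a lower reading in this assay, meaning stronger inhibition of growth. The expected change is an at least 10-fold lower number from compound 1 to compound 3 (1.00 log units; beyond the scatter), an estimate with wide margins, and compound 3 may also end up reported only as a limit. For compound 3 the expected value is 10000 nM, with an estimated range of 1000 nM to 100000 nM.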

Compound 3, concentration for 50% growth inhibition: 100 nM
The estimate for compound 3 lay 100-fold (2.00 log units) above the measured number; measured number outside the range, below it.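

In this assay, the aromatic carbon ortho to the amino group and meta to the large group proves highly sensitive to the choice of substituent, with chloro in place of iodo giving an at least 1000-fold lower number from compound 1 to compound 3 (3.00 log units; beyond the scatter). Compound 3 gives a real reading of 100 nM, so the core of compound 1 can carry strong inhibition of growth once chloro replaces iodo at this one place. Compound 1 gives > 100000 nM, a limit of the assay and not a number, so the step has a bound but no exact size: the limit of > 100000 nM in this assay, at which 1 of the 3 values shown sits.

Going by these compounds, whether the reading follows a trend across this position remains open, since a single pair says nothing about how bromo, fluoro, methyl or plain hydrogen on the same carbon would compare with chloro and iodo. The pair also leaves unsettled whether the chloro reading depends on the neighbouring amino group, which could be tested by setting an acetamide or a dimethylamino group in its place while keeping chloro.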